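Swapping bromo for fluoro on an aromatic carbon

A few compounds are considered here, and "the series" means these few. Any claim that something is new, unique, unknown or untested is made for them only; others in the source may bear on it.

Measured so far, in an assay for binding affinity to adenosine receptor A1 (Bos taurus); on this read-out lower numbers stand for stronger inhibition and higher numbers for weaker inhibition:
- compound 1 `COc1cc(OC)cc(-c2nc3c(=O)n(C)c(=O)n(C)c3[nH]2)c1` gives 500 nM
- compound 2 `CCCn1c(=O)c2nc(-c3ccccc3N)[nH]c2n(CCC)c1=O` gives 0.75 nM
- compound 3 `Cn1c(=O)c2nc(-c3ccc(Br)cc3)[nH]c2n(C)c1=O` gives 0.75 nM

Compound 3 sits level with compound 2 at the digits shown, the two of them together at the low end of the three numbers; the difference between them lies within the usual scatter of this assay, so no order can be read between the two. Compound 1 stands far apart: its number is higher than that of compound 3 by a margin well beyond the scatter.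

Compound 4 `Cn1c(=O)c2nc(-c3ccc(F)cc3)[nH]c2n(C)c1=O` has not yet been measured. It differs from compound 3 in one place: fluoro in place of bromo on an aromatic carbon. The group that leaves and the group that enters are each a single heavy atom, neither adds a ring, a hydrogen-bond donor or an acceptor, and the charge stays the same.

Among the measured compounds shown here, no measured pair in this set shows the effect of such a swap, so the expectation rests on the change itself. A small step upward, within or only slightly beyond the scatter, is expected, a 4.0-fold higher number from compound 3 to compound 4 (0.60 log units; beyond the scatter). Compound 4 is therefore estimated at 3 nM, within a range from 0.8 nM to 12 nM.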

Compound 4, half-maximal inhibitory concentration: 3.5 nM
For compound 4 the middle estimate is 1.2-fold (0.07 log units) below the measured one, and the stated range covers the measured number.
By their numbers in this assay, from the lowest: compounds 2 and 3 (each within the scatter of the next); then compound 4; then compound 1.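

Among the compounds shown here, this is the first pair in the set that differs in one place, so this assay can now be read for a single change: fluoro in place of bromo, on an aromatic carbon para to a large group, gives a 4.7-fold higher number from compound 3 to compound 4 (0.67 log units; beyond the scatter). The step is modest but beyond the usual scatter, which means that this position responds to which halogen it carries, even though the swap exchanges one heavy atom for another and leaves the rings, hydrogen-bond donors, hydrogen-bond acceptors and charge as they were. The data at hand offer no measurement that accounts for this shift.

On these data alone, with only bromo and fluoro seen at this position, it remains open whether chloro or iodo would fall near these two numbers, and whether a non-halogen group such as methoxy or an amine would be tolerated as well. As far as these compounds go, it is also open whether the same swap would give a similar step on a compound with longer chains on the shared core, such as the propyl groups of compound 2.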